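Difluorophenyl in Place of Methoxyphenyl: Compound 4 Expected

This account rests on a few compounds, and the source may have more. Where it says the series, first, only, none or still open, it means among the compounds named here.

Three compounds share a core bearing an aryl group on a five-membered aromatic ring with 1 nitrogen and 1 sulfur. Compound 1 `COc1cc(/C=N/Nc2nc(-c3ccc(Br)cc3)cs2)cc(Br)c1OC` gives 36200 nM in a functional assay on Caco-2 cells (Homo sapiens) for inhibition, read by MTT assay, with a stated time of 48 h (on this read-out higher numbers stand for weaker inhibition and lower numbers for stronger inhibition), and compound 2 `COc1cc(/C=N/Nc2nc(-c3ccccc3)cs2)cc(Br)c1OC` gives 64200 nM. For compound 3 `COc1ccccc1-c1csc(N/N=C/c2cc(Br)c(OC)c(OC)c2)n1` this assay reports only a limit, > 100000 nM. The step of a 1.8-fold higher number from compound 1 to compound 2 (0.25 log units; within the scatter). The step of an at least 2.7-fold higher number from compound 1 to compound 3 (0.44 log units; beyond the scatter), placing compound 3 at the limit (the limit of > 100000 nM in this assay, at which 1 of the 3 values shown sits). The step of an at least 1.5-fold higher number from compound 2 to compound 3 (0.19 log units; that floor lies within the scatter). Compound 4 `COc1cc(/C=N/Nc2nc(-c3ccc(F)c(F)c3)cs2)cc(Br)c1OC` differs from compound 3 by 3,4-difluorophenyl in place of 2-methoxyphenyl on an aromatic carbon. Since compound 1, with its halogen-bearing phenyl, gives 36200 nM, compound 4 is expected to land near compounds 1 and 2. Compound 4 is expected to show a step of an at least 2.0-fold lower number from compound 3 to compound 4 (0.30 log units; that floor lies within the scatter). Compound 4 is estimated at 50000 nM, between 20000 nM and 130000 nM.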

Compound 4, half-maximal inhibitory concentration: 21200 nM
Compound 4: middle estimate off by 2.4-fold (0.37 log units), on the high side; measured number inside the range.
By their numbers in this assay, from the lowest: compounds 4, 1 and 2 (each within the scatter of the next, the first and the last beyond it). At a limit, above all of these: compound 3.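

Replacing 2-methoxyphenyl with 3,4-difluorophenyl gives an at least 4.7-fold lower number from compound 3 to compound 4 (0.67 log units; beyond the scatter), but this step is only a floor, as compound 3 stands at a limit: the limit of > 100000 nM in this assay, at which 1 of the 4 values shown sits.

Against phenyl, the same group gives a 3.0-fold lower number from compound 2 to compound 4 (0.48 log units; beyond the scatter), the first step beyond the scatter at this position that does not rest on a limit. Against 4-bromophenyl, it gives a 1.7-fold lower number from compound 1 to compound 4 (0.23 log units; within the scatter), so these two halogen-bearing phenyl groups cannot be told apart here.

The compounds shown leave open what an amine or a carboxylic acid on this phenyl ring would give.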